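The source may hold more compounds than are shown below. What is called first, only, known or untested is meant among the compounds shown, and "the series" means these compounds.

Measured so far:

compound 1 `C#CCSc1nc(Sc2nccs2)c(C#N)c(-c2ccc(C)cc2)n1` — 2200 nM
compound 2 `C#CCSc1nc(Sc2nc[nH]n2)c(C#N)c(-c2cc(OC)c(OC)c(OC)c2)n1` — a limit only, > 20000 nM

For the measured compounds named here, in a functional assay on MCF7 cells (Homo sapiens) for antiproliferative activity, read by MTT assay, with a stated time of 72 h (a higher number here means a weaker inhibitor, a lower number a stronger inhibitor), compound 1 gives 2200 nM, and this is the only number the series has produced so far. Compound 2, in this assay, returns a limit rather than a number, > 20000 nM. Going by the values given here, the entry the limit of > 20000 nM in this assay, at which 1 of the 2 values shown sits, holds one of the two values shown, so nothing can be said about how far compound 2 lies from compound 1, only that its value is on the far side of that limit.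

Compound 3 `C#CCSc1nc(Sc2nccs2)c(C#N)c(-c2ccc(Cl)cc2)n1` has not yet been measured. It differs from compound 1 in one place: chloro in place of methyl on an aromatic carbon. Among the compounds with values here, no step between measured compounds exists to calibrate a change of this kind, so the expectation rests on the size of the change alone. A single heavy atom swapped for another on the same aromatic carbon is expected to move this assay little: the estimated step of a 1.2-fold lower number from compound 1 to compound 3 (0.09 log units; within the scatter) from compound 1 to compound 3 is taken to sit within the usual scatter, with no clear direction. Compound 3 is accordingly expected to give about 1800 nM, with a range from 600 nM to 5500 nM.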

Compound 3, half-maximal inhibitory concentration: 3230 nM
Beside the measured number, compound 3's estimate is 1.8-fold (0.25 log units) below it; low and high end bracket the measured number.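

In this assay the series now has its first readable step at a single place: on an aromatic carbon para to a large group, going from 4-methylphenyl to 4-chlorophenyl gives a 1.5-fold higher number from compound 1 to compound 3 (0.17 log units; within the scatter) and so does not separate the two compounds. This position therefore accepts chloro in place of methyl with a measured result that stays within the scatter, so methyl is not shown to be needed there, and neither group can be ranked over the other. No measured property shown here bears on this step, and no explanation of it can be drawn from the data.

Open, going by these compounds, is whether this position responds to anything larger or different in kind, such as an amine, a carboxylic acid or a longer chain on the same aromatic carbon, since methyl and chloro are single heavy atoms and test only a narrow change. Also open, on these data alone, is whether the exchange of methyl for chloro would give a step of similar size on a compound that differs from compound 1 elsewhere on the shared core.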